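Swapping 2-fluorophenyl for 4-fluorophenyl: working notes

The source may report more compounds than this note shows. Statements on the series, on what has been measured and on what is new or still open speak of the compounds shown alone.

Measured in a functional assay on A549 cells (Homo sapiens) for antiproliferative activity, read by MTT assay, with a stated time of 24 h; a higher number here means a weaker inhibitor, a lower number a stronger inhibitor:
- compound 1 `Cc1ccccc1NNC(=O)c1cccc(NS(=O)(=O)c2cnc(O)nc2O)c1`: 14200 nM
- compound 2 `O=C(NNC(=O)c1ccccc1F)c1cccc(NS(=O)(=O)c2cnc(O)nc2O)c1`: 10800 nM

Compound 2 gives 10800 nM and stands level with compound 1 at 14200 nM, as the two values lie within the scatter of each other. Among the compounds with values here, only one measured step exists in this small set: a 1.3-fold lower number from compound 1 to compound 2 (0.12 log units; within the scatter). It puts (2-fluorophenyl)carbonyl in place of 2-methylphenyl on an amine nitrogen, and it stays within the scatter.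

Compound 3 `O=C(NNC(=O)c1cccc(NS(=O)(=O)c2cnc(O)nc2O)c1)c1ccc(F)cc1` is the next case, with 4-fluorophenyl in place of 2-fluorophenyl on a carbonyl carbon. Within the data shown here, no measured pair tests this exchange directly, so the single step above bears on it only indirectly, as a change of a different kind. That step gives no direction to carry over, and the data hold no other guide. The working expectation therefore starts from compound 2 at 10800 nM, with no change beyond the scatter in this assay. The expected move is a 1.0-fold higher number from compound 2 to compound 3 (0.01 log units; within the scatter). For compound 3 the estimated value is 11000 nM, within an expected range of 5000 nM to 24000 nM.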

Compound 3, half-maximal inhibitory concentration: > 20000 nM
Compound 3 gave a limit, no number; the forecaster's own chance of this, stated with the estimate: 5%; middle value at least 1.8-fold (0.25 log units) from the limit.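

This is the first exchange shown on the carbonyl carbon itself, and in this assay compound 3 gives > 20000 nM, which is a limit and not a number. Read from that limit, the change of 2-fluorophenyl to 4-fluorophenyl is an at least 1.8-fold higher number from compound 2 to compound 3 (0.26 log units; that floor lies within the scatter), so the two isomers, which have the same atoms joined differently, cannot be ranked, although the fluorine position is not shown to be without consequence, since only a floor is available. The wider comparison, which replaces 2-methylphenyl on an amine nitrogen with (4-fluorophenyl)carbonyl, is an at least 1.4-fold higher number from compound 1 to compound 3 (0.14 log units; that floor lies within the scatter), so it too gives a floor and no firm separation, and the record for this series carries only the one limit: the limit of > 20000 nM in this assay, at which 1 of the 3 values shown sits.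

The size of any real shift between the 2-fluorophenyl and 4-fluorophenyl forms stays open, and no reason for it can be drawn from these compounds. Also open, going by these compounds, is how a plain phenyl, a chlorophenyl or a methoxyphenyl on the same carbonyl carbon would read against compound 2 at 10800 nM.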